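This account rests on a few compounds, and the source may have more. Where it says the series, first, only, none or still open, it means among the compounds named here.

In a functional assay on DU-145 cells (Homo sapiens) for inhibition, read by trypan blue exclusion, with a stated time of 96 h (a lower number here means a stronger inhibitor of growth, a higher number a weaker inhibitor of growth), compound 1, `CCOc1ccc(/C=C(/Sc2ccc(C)cc2)C(=O)c2ccc(Cl)cc2)cc1OC`, gives 25000 nM, and it has the lowest of the two numbers that have been measured. Its nearest neighbour is compound 2, `Cc1ccc(S(=O)(=O)/C(=C/c2ccc(C)s2)C(=O)c2ccc(Cl)cc2)cc1`, which in this assay gives 50000 nM; the two numbers lie within the scatter of each other, so no order can be read between them. Within the data shown here, compound 2 already carries a sulfonyl group on the chain, though its other ring is different, so the pair offers no clean step and only shows that both compounds sit in the same weak range.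

Compound 3, `CCOc1ccc(/C=C(\C(=O)c2ccc(Cl)cc2)S(=O)(=O)c2ccc(C)cc2)cc1OC`, has not been measured. It differs from compound 1 in one place: (4-methylphenyl)sulfonyl in place of (4-methylphenyl)sulfanyl on a double-bonded chain carbon bound to a carbonyl carbon and a double-bonded chain carbon. Among the measured compounds shown here, no measured step isolates this change. Given that compound 2, which also carries the sulfonyl, gives 50000 nM, the account expects no step beyond the scatter, if anything a slightly higher number, as a 1.4-fold higher number from compound 1 to compound 3 (0.15 log units; within the scatter). Compound 3 is therefore estimated at 35000 nM in this assay, within a range from 12000 nM to 100000 nM.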

Compound 3, concentration for 50% growth inhibition: 1000 nM
Beside the measured number, compound 3's estimate is 35-fold (1.54 log units) above it; measured number below the stated range.
By their numbers in this assay, from the lowest: compound 3; then compounds 1 and 2 (each within the scatter of the next).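

Among these compounds, at this place on a double-bonded chain carbon bound to a carbonyl carbon and a double-bonded chain carbon, the exchange of (4-methylphenyl)sulfanyl for (4-methylphenyl)sulfonyl gives, in this assay, a 25-fold lower number from compound 1 to compound 3 (1.40 log units; beyond the scatter), the first step between these compounds that can be read and one well beyond the scatter. Among the compounds shown here, this shows that the core of compound 1 is sensitive to the group at this place, and that two added oxygen atoms on the sulfur are enough to separate compound 3 from the weak range of the earlier compounds. Carrying the sulfonyl does not by itself ensure a low number, as compound 2, which has the same group with a different ring on the chain, gives 50000 nM; no measured property accounts for the step.

As far as these compounds go, whether a sulfinyl group or an amide at this same place would give a number near that of compound 3 remains open. From the compounds shown here alone, it also remains open whether the step would hold if a morpholine or a carboxylic acid replaced the 4-methylphenyl ring on the sulfonyl.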